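The compounds below may be only part of what the source reports. "The series", "measured", "known", "first", "only" and "open" are said of these compounds alone.

Measured compounds:
compound 1 `COc1cc2c(Oc3ccc(NC(=O)/C=C/S(=O)(=O)c4ccccc4OC)cc3F)ccnc2cc1OCCCN1CCN(C)CC1` gives 320 nM in a functional assay on A549 cells (Homo sapiens) for cytotoxicity, read by MTT assay, with a stated time of 72 h; on this read-out higher numbers stand for weaker inhibition and lower numbers for stronger inhibition
compound 2 `COc1ccc(S(=O)(=O)/C=C/C(=O)Nc2ccc(Oc3ccnc4cc(OCCCN5CCN(C)CC5)c(OC)cc34)c(F)c2)cc1` gives 1870 nM
compound 3 `COc1cc2c(Oc3ccc(NC(=O)/C=C/S(=O)(=O)c4ccccc4OC)cc3F)ccnc2cc1OCCCN1CCCCC1` gives 470 nM

In this assay compound 3 stands second highest of the three numbers, nearest to compound 1 and furthest from compound 2. Compound 4 `COc1ccc(S(=O)(=O)/C=C/C(=O)Nc2ccc(Oc3ccnc4cc(OCCCN5CCCCC5)c(OC)cc34)c(F)c2)cc1` is not yet measured. The change from compound 3 to compound 4 is 4-methoxyphenyl in place of 2-methoxyphenyl on a sulfonyl sulfur. Within the data shown here, the one measured step that bears on it is the same swap made on compound 1, which gave a 5.8-fold higher number from compound 1 to compound 2 (0.77 log units; beyond the scatter), a modest rise beyond the scatter. The step from compound 1 to compound 3 was a 1.5-fold higher number from compound 1 to compound 3 (0.17 log units; within the scatter), so the chain change did not alter the picture. A rise of similar size is therefore expected, read as a 5.7-fold higher number from compound 3 to compound 4 (0.76 log units; beyond the scatter). Compound 4 is estimated at 2700 nM, with a range from 1300 nM to 5600 nM.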

Compound 4, half-maximal inhibitory concentration: 2220 nM
For compound 4 the middle estimate is 1.2-fold (0.09 log units) above the measured one; measured number inside the range.
By their numbers in this assay, from the lowest: compounds 1 and 3 (each within the scatter of the next); then compounds 2 and 4 (each within the scatter of the next).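

In this assay, 4-methoxyphenyl in place of 2-methoxyphenyl on the sulfonyl sulfur also raises the number with the piperidin-1-yl chain end, a 4.7-fold higher number from compound 3 to compound 4 (0.67 log units; beyond the scatter), so the rise is no longer seen on one core alone: the same change on two cores in this assay, a 5.8-fold higher number (0.77 log units; beyond the scatter) from compound 1 to compound 2 and a 4.7-fold higher number (0.67 log units; beyond the scatter) from compound 3 to compound 4, 1.2-fold (0.09 log units) apart, within the scatter of two such steps

With 4-methoxyphenyl in place, the chain-end swap also stays within the scatter, a 1.2-fold higher number from compound 2 to compound 4 (0.07 log units; within the scatter), so it makes no readable difference with either sulfonyl group: the same change on two cores in this assay, a 1.5-fold higher number (0.17 log units; within the scatter) from compound 1 to compound 3 and a 1.2-fold higher number (0.07 log units; within the scatter) from compound 2 to compound 4, 1.2-fold (0.09 log units) apart, within the scatter of two such steps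

Open, on these data alone, is whether a plain phenyl on the sulfonyl sulfur would fall with the 2-methoxyphenyl compounds or the 4-methoxyphenyl compounds. Also open, as far as these compounds go, is whether morpholin-4-yl at the chain end would match piperidin-1-yl and 4-methylpiperazin-1-yl.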